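Methylpyridyl variation on the fluorophenyl-tetrazole series

This account rests on a few compounds, and the source may have more. Where it says the series, first, only, none or still open, it means among the compounds named here.

Measured compounds:
compound 1 `Cc1cccnc1-c1cc(F)cc(-n2nnc(-c3ccccn3)n2)c1` 31 nM
compound 2 `Cc1cnccc1-c1cc(F)cc(-n2nnc(-c3ccccn3)n2)c1` 63 nM
compound 3 `Cc1ccncc1-c1cc(F)cc(-n2nnc(-c3ccccn3)n2)c1` 5 nM

In a functional assay for antagonist activity at metabotropic glutamate receptor 5 (Rattus norvegicus) (on this read-out lower numbers stand for stronger inhibition and higher numbers for weaker inhibition), compound 3 stands lowest of the three numbers; its steps to compound 1 and compound 2 are both beyond the scatter, so it is the most potent of the measured set. The step from compound 1 to compound 3 was a 6.2-fold lower number from compound 1 to compound 3 (0.79 log units; beyond the scatter) and from compound 2 to compound 3 a 13-fold lower number from compound 2 to compound 3 (1.10 log units; beyond the scatter); between compound 1 and compound 2 the step was a 2.0-fold higher number from compound 1 to compound 2 (0.31 log units; beyond the scatter). All three steps move the ring nitrogen of the methylpyridyl group.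

Compound 4 `Cc1ccc(-c2cc(F)cc(-n3nnc(-c4ccccn4)n3)c2)cn1` differs from compound 3 by 6-methylpyridin-3-yl in place of 4-methylpyridin-3-yl on an aromatic carbon. The ring nitrogen keeps its place; only the methyl moves. Within the data shown here, no measured step moves the methyl alone, so the bearing of the nitrogen-position steps on this change is indirect. Given that compound 3 already gives 5 nM as the best number, a modest rise toward the level of compound 1 is expected, though a number near compound 3 cannot be excluded.

The expected step from compound 3 to compound 4 is a 3.0-fold higher number from compound 3 to compound 4 (0.48 log units; beyond the scatter). Compound 4 is estimated at 15 nM, within 4 nM to 60 nM.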

Compound 4, half-maximal inhibitory concentration: 57 nM
The estimate for compound 4 lay 3.8-fold (0.58 log units) below the measured number, within the range that was stated.
By their numbers in this assay, from the lowest: compound 3; then compounds 1, 4 and 2 (each within the scatter of the next, the first and the last beyond it).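

In this assay, moving the methyl alone, with the ring nitrogen kept in place, gives a large step (an 11-fold higher number from compound 3 to compound 4 (1.06 log units; beyond the scatter)), so the pyridin-3-yl attachment shared by compound 3 and compound 4 is not enough on its own for the low number of compound 3. Compound 4 stays within the scatter of both other isomers (a 1.1-fold lower number from compound 2 to compound 4 (0.04 log units; within the scatter); a 1.8-fold higher number from compound 1 to compound 4 (0.26 log units; within the scatter)), and among the four methylpyridyl groups shown, only the 4-methylpyridin-3-yl group of compound 3 stands clearly apart. Nothing available on these compounds explains why this placement of the methyl matters.

Still open, from the compounds shown here alone, is whether the methyl of the 4-methylpyridin-3-yl group is itself needed, or whether an ethyl, a methoxy group or an amine could take its place. Also open, going by these compounds, is how an unsubstituted pyridin-3-yl group would compare with compound 3 and compound 4.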